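The source may report more compounds than this note shows. Statements on the series, on what has been measured and on what is new or still open speak of the compounds shown alone.

Among the compounds with values here, only two compounds have numbers so far in a functional assay on cells (Mast cell, Rattus norvegicus, strain Wistar) for activation, read by fluorescence, with a stated time of 15 min; on this read-out lower numbers stand for an effect already at smaller amounts and higher numbers for an effect only at larger amounts of compound. Compound 1 (`CCCCCCCCCCCCCCCCCC(=O)CCCCOP(=O)(O)OC[C@H](N)C(=O)O`) gives 5000 nM. Compound 2 (`CCCCCCCCCCCCCCCCCC(=O)OC[C@@H](O)COP(=O)(O)O[C@@H](C)[C@H](N)C(=O)O`) gives 2000 nM, the lower of the two numbers, and the gap between them lies beyond the usual scatter. Compound 3 (`CCCCCCCCCCCCCCCCCC(=O)OC[C@@H](O)COP(=O)(O)OC[C@H](N)C(=O)OC`) has not yet been measured in this assay. It has the same atoms as compound 2, joined differently: a group of 7 heavy atoms (4 carbon, 1 nitrogen, 2 oxygen; no ring) in place of a group of 7 heavy atoms (4 carbon, 1 nitrogen, 2 oxygen; no ring), on an oxygen. The 2-amino-2-(methoxycarbonyl)ethyl group that enters sits on an oxygen whose other neighbour is phosphorus. Within the data shown here, the two measured compounds do not form a pair differing in one place, so the data contain no measured step to serve as a guide. Among the measured compounds shown here, neither compound 1 nor compound 2 carries a methoxycarbonyl, so this change has no direct precedent here. A moderate move toward a higher number, beyond the scatter, is therefore expected, though with low confidence. The expected size of this move is a 3.0-fold higher number from compound 2 to compound 3 (0.48 log units; beyond the scatter). For compound 3 the estimated value is 6000 nM, with an expected range from 1500 nM to 30000 nM.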

Compound 3, half-maximal effective concentration: > 10000 nM
Compound 3: no number, only a limit; the forecaster's own chance of this, stated with the estimate: 30%; middle value at least 1.6-fold (0.22 log units) from the limit.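

In this assay compound 3 gives > 10000 nM, a limit of the assay and not a number. The first step measured at this position shows that the read-out responds to how the same atoms are joined: placing the 2-amino-2-(methoxycarbonyl)ethyl group on an oxygen whose other neighbour is phosphorus gives an at least 5.0-fold higher number from compound 2 to compound 3 (0.69 log units; beyond the scatter), so the change goes in the unfavourable direction and lies beyond the scatter. Only a lower bound on the size of this step can be given, and its true size remains undetermined: the limit of > 10000 nM in this assay, at which 1 of the 3 values shown sits.

The compounds shown do not separate what the methoxycarbonyl contributes from what is lost with the group that leaves, since both the entering and the leaving groups differ as whole units and this single pair offers no finer comparison. They also leave open how a 2-amino-2-(ethoxycarbonyl)ethyl group or a carboxamide on the same oxygen would read out, and whether either would bring the number back toward that of compound 2.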